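Benzothiophene Amide to Dihydroxypropyl Amide: Lung Exposure Outlook

The source may report more compounds than this note shows. Statements on the series, on what has been measured and on what is new or still open speak of the compounds shown alone.

Compound 1 `NCc1cc(Oc2cccc(C(=O)NCCS(N)(=O)=O)c2)nc(C(F)(F)F)c1`: 540 nM in an ADME assay on the whole organism (lung, Mus musculus) for pharmacokinetics, read by LC-MS, at a dose of 30 mg/kg by the oral route; a lower number here means less compound in the circulation, a higher number more compound in the circulation at the dose given
Compound 2 `NCc1cc(Oc2cccc(C(=O)NCc3cc4ccccc4s3)c2)nc(C(F)(F)F)c1`: "not determined" (no result reported) in this assay

Going by these compounds, compound 2 stands without a number in this assay: no maximal plasma concentration was reported for it, so its place on the scale is unknown. Compound 3 `NCc1cc(Oc2cccc(C(=O)NC[C@@H](O)CO)c2)nc(C(F)(F)F)c1` differs from compound 2 in one place, (1,2-dihydroxyethyl in place of 1-benzothiophen-2-yl on a saturated chain carbon bound to an amide-type nitrogen). With no value for compound 2, neither the size nor the direction of the step to compound 3 in this assay can be anchored. Taking compound 1 and its 540 nM as the only measured point, compound 3 is estimated at 500 nM, expected to fall between 150 nM and 1600 nM.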

Compound 3, maximal plasma concentration: 1920 nM
Compound 3: the middle estimate sits 3.8-fold (0.58 log units) below what was measured, outside the stated range (above it).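

In this assay, this position, on a saturated chain carbon bound to an amide-type nitrogen, now has its first readable comparison: 1,2-dihydroxyethyl in place of sulfamoylmethyl gives a 3.6-fold higher number from compound 1 to compound 3 (0.55 log units; beyond the scatter) and shows that changing this group alone can shift the read-out. Compound 2 has no value, so the step from compound 2 to compound 3 cannot be read. Nothing shown accounts for the rise. Going by these compounds, it remains open how a carboxylic acid or a longer chain bearing hydroxyl groups would read at this position. On these data alone, the mirror-image form of the 1,2-dihydroxyethyl group also remains open.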